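Three Compounds at a Cytotoxicity Limit, a Fourth Expected

This account rests on a few compounds, and the source may have more. Where it says the series, first, only, none or still open, it means among the compounds named here.

Compound 1 `O=[N+]([O-])c1cn2c(n1)OCC(COc1ccc(-c3ccc(OC(F)(F)F)cc3)cn1)C2`: > 128000 nM, which is a limit of the assay.
Compound 2 `O=[N+]([O-])c1cn2c(n1)OCC(COc1ccc(-c3ccc(C(F)(F)F)cc3)cn1)C2`: > 128000 nM, also a limit.
Compound 3 `O=[N+]([O-])c1cn2c(n1)OCC(COc1ccc(-c3ccc(OC(F)(F)F)cc3)nc1)C2`: > 128000 nM, also a limit.

All three values come from an ADME assay on Vero cells (Chlorocebus sabaeus) for cytotoxicity, with a stated time of 72 h; on this read-out lower numbers stand for stronger inhibition and higher numbers for weaker inhibition. The change from compound 1 to compound 2 is trifluoromethyl in place of trifluoromethoxy on an aromatic carbon, and the step it made is a step that the two limits leave unreadable from compound 1 to compound 2. The difference between the core of compound 1 and the core of compound 3 is not broken down here. Compound 4 `O=[N+]([O-])c1cn2c(n1)OCC(COc1ccc(-c3ccc(C(F)(F)F)cc3)nc1)C2` has not yet been measured in this assay; it differs from compound 3 by trifluoromethyl in place of trifluoromethoxy on an aromatic carbon, the same change, at the same place, as that from compound 1 to compound 2. Because the limit of > 128000 nM in this assay, at which 3 of the 3 values shown sit, holds for every measured compound, the step from compound 3 to compound 4 is expected to be a step that the limit leaves unreadable from compound 3 to compound 4. Compound 4 is therefore estimated at 150000 nM in this assay, most likely again reported only as a limit.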

Compound 4, half-maximal inhibitory concentration: > 128000 nM
Compound 4: no number, only a limit; the forecaster's own chance of this, stated with the estimate: 85%; the middle value is on the limit's open side.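

No step can be read from compound 3 to compound 4, since both results are limits and not numbers: the limit of > 128000 nM in this assay, at which 4 of the 4 values shown sit.

In this assay the compounds shown leave open whether trifluoromethyl and trifluoromethoxy differ at all, and at what concentration any of these compounds would give a number.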